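Cytotoxicity of a Quinolone Series on Liver Cells

The compounds below may be only part of what the source reports. "The series", "measured", "known", "first", "only" and "open" are said of these compounds alone.

Three compounds sharing a common core were tested in an ADME assay on Huh-7 cells (Homo sapiens) for cytotoxicity; a lower number here means a stronger inhibitor of growth, a higher number a weaker inhibitor of growth. Compound 1 `O=C(OCc1ccc(Cl)cc1)c1cn(Cc2ccc(Cl)cc2)c2cc(N3CCNCC3)c(F)cc2c1=O` gives 1100 nM. Compound 3 `COc1cc2c(=O)c(C(=O)OCc3ccccc3C)cn(Cc3ccc(C(F)(F)F)cc3F)c2cc1OC` gives 31000 nM, a weaker inhibitor of growth. Compound 2 `COc1cc2c(=O)c(C(=O)c3ccc(C)cc3)cn(Cc3ccc(Cl)c(Cl)c3)c2cc1OC` was reported as "not active" (no number reported), so no single number exists for it; it stands at the weak end of what has been seen here. Compound 4 `COc1cc2c(=O)c(C(=O)c3ccc(C)cc3)cn(Cc3ccc(N)cc3)c2cc1OC` carries the change (4-aminophenyl in place of 3,4-dichlorophenyl on a saturated chain carbon bound to an aromatic nitrogen). Among the compounds with values here, no measured pair shows this change, so its effect is unknown; with compound 2 inactive, the expectation is that compound 4 stays a weak inhibitor of growth, with any step staying within the scatter or slightly stronger. Compound 4 is estimated at 40000 nM, between 10000 nM and 150000 nM, in this assay .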

Compound 4, concentration for 50% growth inhibition: "not active" (no number reported)
For compound 4 the study gives words and no number; there is nothing to compare the estimate with.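

Compound 2 and compound 4 are both reported in words only in this assay, so no step can be read between them. On these data alone, whether 3,4-dichlorobenzyl to 4-aminobenzyl changes growth inhibition stays open, and no further evidence bears on this result.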